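Swapping One Aromatic Group on a Shared Core

This account rests on a few compounds, and the source may have more. Where it says the series, first, only, none or still open, it means among the compounds named here.

Measured in a functional assay on MDA-MB-231 cells (Homo sapiens) for antiproliferative activity, read by MTT assay, with a stated time of 72 h; a higher number here means a weaker inhibitor, a lower number a stronger inhibitor:
Compound 1 `CC1=CC[C@H]2[C@H](CC[C@]2(C)O)C(C)(C)[C@@H]1CC[C@H]1[C@]2(C)CC[C@H](OC(=O)CCC(=O)O)C(C)(C)O[C@H]2CC[C@@]1(C)O`: 27900 nM
Compound 2 `CC1=CC[C@H]2[C@H](CC[C@]2(C)O)C(C)(C)[C@@H]1CC[C@H]1[C@]2(C)CC[C@H](OC(=O)c3ccc(Cl)cc3)C(C)(C)O[C@H]2CC[C@@]1(C)O`: 10300 nM
Compound 3 `CC1=CC[C@H]2[C@H](CC[C@]2(C)O)C(C)(C)[C@@H]1CC[C@H]1[C@]2(C)CC[C@H](OC(=O)c3cccc(C(F)(F)F)c3)C(C)(C)O[C@H]2CC[C@@]1(C)O`: 36300 nM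

Compound 3 gives 36300 nM, which places it with compound 1 at the weak end of this small set. The values show a 1.3-fold higher number from compound 1 to compound 3 (0.11 log units; within the scatter), so the two cannot be told apart. The clear gap is a 3.5-fold higher number from compound 2 to compound 3 (0.55 log units; beyond the scatter).

Compound 4 `CC1=CC[C@H]2[C@H](CC[C@]2(C)O)C(C)(C)[C@@H]1CC[C@H]1[C@]2(C)CC[C@H](OC(=O)c3ccc(C(F)(F)F)cc3F)C(C)(C)O[C@H]2CC[C@@]1(C)O` keeps the shared core and has 2-fluoro-4-(trifluoromethyl)phenyl in place of 3-(trifluoromethyl)phenyl on a carbonyl carbon. Among the measured compounds shown here, none of the measured compounds carries this new group, so no step tests it directly. For the measured compounds named here, the closest guide is the one exchange of an aromatic group for another, a 3.5-fold higher number from compound 2 to compound 3 (0.55 log units; beyond the scatter), which is modest. The other step that goes beyond the scatter, a 2.7-fold lower number from compound 1 to compound 2 (0.43 log units; beyond the scatter), is modest too. Changes at this place have therefore moved the number only moderately so far. Compound 2 gives 10300 nM, so a small move toward a lower number seems somewhat more likely than a move the other way. The step expected in this assay is a 1.7-fold lower number from compound 3 to compound 4 (0.22 log units; within the scatter), and it is only an estimate. For compound 4 the estimated value is 22000 nM, with an expected range from 9000 nM to 50000 nM.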

Compound 4, half-maximal inhibitory concentration: 36300 nM
The estimate for compound 4 lay 1.7-fold (0.22 log units) below the measured number, and the stated range covers the measured number.
By their numbers in this assay, from the lowest: compound 2; then compounds 1, 3 and 4 (each within the scatter of the next).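

In this assay, exchanging 3-(trifluoromethyl)phenyl for 2-fluoro-4-(trifluoromethyl)phenyl on the carbonyl carbon gives no change at the digits printed from compound 3 to compound 4 (within the scatter), so this pair of aromatic groups cannot be told apart at this position. The new group also falls on the weak side of the one clear gap in the set, with a 3.5-fold higher number from compound 2 to compound 4 (0.55 log units; beyond the scatter), while the comparison with the non-aromatic group gives a 1.3-fold higher number from compound 1 to compound 4 (0.11 log units; within the scatter). With a second aromatic group now showing this pattern, the 4-chlorophenyl group of compound 2 stands alone as the strongest of these four compounds, and neither trifluoromethyl-bearing group shares its lower number, although one more example still describes only these compounds.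

No measurement given here bears on the reason for these numbers. An unsubstituted phenyl group or a 4-bromophenyl group on the same carbonyl carbon would help show whether the lower number of compound 2 goes with the chlorine atom or with something more general, and an amine on the aromatic ring would test a very different kind of group at this place.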